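From compound 1 to compound 3: a step without anchor

This account rests on a few compounds, and the source may have more. Where it says the series, first, only, none or still open, it means among the compounds named here.

Compound 1 (`CS(=O)(=O)c1ccc(-n2nc(C(F)F)c(C#N)c2-c2cc(F)cc(F)c2)cc1`) offers no number to start from: in a physicochemical assay for solubility (on this read-out lower numbers stand for lower solubility and higher numbers for higher solubility), compound 1 is recorded as "not determined" (no result reported). Among the compounds with values here, the only number available comes from compound 2 (`CC1CCCN(c2c(C#N)c(C(F)(F)F)nn2-c2ccc(S(C)(=O)=O)cn2)C1`), which gives 100 ug/mL. Compound 3 (`CC(C)(C)CNc1c(C#N)c(C(F)F)nn1-c1ccc(S(C)(=O)=O)cc1`) has not yet been measured. The structural change is neopentylamino in place of 3,5-difluorophenyl on an aromatic carbon, with neopentylamino in place of 3,5-difluorophenyl on an aromatic carbon, and the entering group has no ring. Without a starting value, the size of the step in this assay cannot be read from the data. A moderate upward step is expected, but it remains unanchored. The estimate therefore rests loosely on compound 2 at 100 ug/mL, set somewhat lower and with a wide range. Compound 3 is expected at 40 ug/mL, within an estimated range of 10 ug/mL to 130 ug/mL.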

Compound 3, solubility: > 200 ug/mL
Compound 3 gave a limit, no number; the forecaster's own chance of this, stated with the estimate: 10%; at least 5.0-fold (0.69 log units) between middle value and limit.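

Within the data shown here, no step from compound 1 to compound 3 can be read in this assay; compound 3 gives > 200 ug/mL, a limit and not a number. The compounds shown leave open how neopentylamino compares with 3,5-difluorophenyl on the shared core in this read-out.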